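A few compounds are considered here, and "the series" means these few. Any claim that something is new, unique, unknown or untested is made for them only; others in the source may bear on it.

Compound 1 `O=C(/C=C/C=C/c1ccccc1)c1c(O)c2ccccc2[nH]c1=O` has been tested in an ADME assay on THP-1 cells (Homo sapiens) for cytotoxicity, read by MTT assay, with a stated time of 72 h (a lower number here means a stronger inhibitor, a higher number a weaker inhibitor), where compound 1 gives > 50000 nM, which is a limit of the assay and not a number. Compound 2 `CC(/C=C/C(=O)c1c(O)c2ccccc2[nH]c1=O)=C\c1ccccc1` gives > 50000 nM in this assay, again a limit rather than a number. Compound 3 `CC(C)(C)c1cc(/C=C/C(=O)c2c(O)c3ccccc3[nH]c2=O)cc(C(C)(C)C)c1O` gives 26200 nM in this assay. Within the data shown here, the only step between measured compounds, a step that the two limits leave unreadable from compound 1 to compound 2, is methyl in place of hydrogen on a double-bonded chain carbon bound to two double-bonded chain carbons, and its size stays unreadable because the limit of > 50000 nM in this assay, at which 2 of the 3 values shown sit, covers both of its ends. Compound 4 `Cc1ccccc1/C=C/C(=O)c1c(O)c2ccccc2[nH]c1=O` has not yet been measured in this assay. It differs from compound 1 by 2-methylphenyl in place of 2-phenylethenyl on a double-bonded chain carbon bound to a double-bonded chain carbon. Among the measured compounds shown here, no measured step touches this change, and every value shown sits at or near the top of the measured range, so no readable step from compound 1 is expected. Compound 4 is therefore expected to give about 60000 nM in this assay, with a range from 25000 nM to 150000 nM, and most likely to be reported only as a limit. The step that the limit leaves unreadable from compound 1 to compound 4 is estimated to stay within the usual scatter.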

Compound 4, half-maximal inhibitory concentration: > 50000 nM
Compound 4: no number, only a limit; the forecaster's own chance of this, stated with the estimate: 70%; the middle value is on the limit's open side.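

No step can be read from compound 1 to compound 4, because both results are limits of the assay and not numbers: the limit of > 50000 nM in this assay, at which 3 of the 4 values shown sit. Left open is whether compound 1, compound 2 and compound 4 truly differ from one another in this assay or merely share that limit.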